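The source may hold more compounds than are shown below. What is called first, only, known or untested is meant among the compounds shown, and "the series" means these compounds.

Measured compounds:
- Compound 1, `CCCC[S+]([O-])c1sc2nc(-c3nccs3)cc(-c3ccc(C(=O)OC)cc3)c2c1N`: 15.1 nM
- Compound 2, `CCCC[S+]([O-])c1sc2nc(-c3ccccc3)nc(-c3ccccc3)c2c1N`: 4.9 nM
- Compound 3, `CCCC[S+]([O-])c1sc2nc(-c3nccs3)cc(-c3ccc(CNS(C)(=O)=O)cc3)c2c1N`: 4.6 nM

In an assay for inhibition of 15-hydroxyprostaglandin dehydrogenase [NAD(+)] (Homo sapiens), read by fluorescence, with a stated time of 15 min, in the presence of a further agent that is not named here (a higher number here means a weaker inhibitor, a lower number a stronger inhibitor), compound 3 gives the lowest of the three numbers. Compound 2 sits closest to it, within the scatter, so the two cannot be ordered; compound 1 is furthest from it, beyond the scatter. For the measured compounds named here, the one step measured in one place, a 3.3-fold lower number from compound 1 to compound 3 (0.52 log units; beyond the scatter), is the only step that bears on the change now considered, since it also alters the group on the aromatic carbon of the same phenyl ring.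

Compound 4, `CCCC[S+]([O-])c1sc2nc(-c3nccs3)cc(-c3ccc(CO)cc3)c2c1N`, differs from compound 3 by hydroxy in place of methanesulfonamido on a saturated chain carbon bound to an aromatic carbon. The methanesulfonamido group leaves, and a hydroxy group enters on the same saturated chain carbon. The measured step shows that this position tolerates a change of group, with a modest shift. Going by the values given here, with no directly comparable pair, a step within the scatter, or a small rise in the number, is expected for a 1.5-fold higher number from compound 3 to compound 4 (0.18 log units; within the scatter). Compound 4 is estimated at 7 nM, with a range from 3 nM to 20 nM.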

Compound 4, half-maximal inhibitory concentration: 2.5 nM
For compound 4 the middle estimate is 2.8-fold (0.45 log units) above the measured one; the measured number lies below the stated range.
By their numbers in this assay, from the lowest: compounds 4, 3 and 2 (each within the scatter of the next); then compound 1.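

In this assay the step of a 1.8-fold lower number from compound 3 to compound 4 (0.26 log units; within the scatter) shows that hydroxy, with 1 heavy atom, serves on this saturated chain carbon as well as methanesulfonamido, with 5 heavy atoms, so the sulfonyl part of the earlier group is not needed to hold the number in this range. The second step of a 6.0-fold lower number from compound 1 to compound 4 (0.78 log units; beyond the scatter) shows that the gain over methoxycarbonyl on the aromatic carbon is not tied to methanesulfonamido, since hydroxymethyl also stands beyond the scatter from compound 1. Nothing given here accounts for either step.

Going by these compounds, what a primary amine, a methyl ether or a carboxylic acid would give on this chain carbon remains open. So does whether a longer chain carrying the hydroxy would keep the number in this range.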